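The source may report more compounds than this note shows. Statements on the series, on what has been measured and on what is new or still open speak of the compounds shown alone.

Measured compounds:

Compound 1 `O=C1C=CC(OC(C(F)(F)F)C(F)(F)F)N1c1ccc(Cl)cc1` gives 4480 nM in a functional assay on K562 cells (Homo sapiens) for inhibition; on this read-out higher numbers stand for weaker inhibition and lower numbers for stronger inhibition.
Compound 2 `CC(C)c1ccc(N2C(=O)C=CC2OCC(F)(F)F)cc1` gives 6620 nM in this assay.
Compound 3 `O=C1C=CC(OCC(F)(F)F)N1c1cc(Cl)cc(Cl)c1` gives 1640 nM in this assay.

All three share a core carrying an aromatic ring on the nitrogen and a fluorinated alkoxy group on the ring carbon, and differ in what sits on the aromatic ring. Compound 2 stands at the high end of these numbers. Its result sits close to that of compound 1, with the gap between them inside the usual scatter of repeated measurements, so no order can be read between those two. Compound 3, with two chlorines on the aromatic ring, is set apart from compound 2 by a gap beyond the scatter.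

The next compound, compound 4 `O=C1C=CC(OCC(F)(F)F)N1c1ccccc1`, has not yet been measured in this assay. It follows from compound 2 by one change: hydrogen in place of isopropyl on an aromatic carbon. Within the data shown here, no pair of measured compounds shows this change on its own, so the expected step rests on the whole set rather than on a direct precedent. The substituents on the aromatic ring vary across compounds 1 to 3 without any of them being this change, and the stripping of the isopropyl is expected to leave the number roughly where compound 2 sits. Compound 4 is estimated at 7500 nM, with a range from 2500 nM to 22000 nM. The expected step of a 1.1-fold higher number from compound 2 to compound 4 (0.05 log units; within the scatter) is estimated to be none beyond the scatter.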

Compound 4, half-maximal inhibitory concentration: 24600 nM
Compound 4: the middle estimate sits 3.3-fold (0.52 log units) below what was measured; measured number above the stated range.
By their numbers in this assay, from the lowest: compound 3; then compounds 1 and 2 (each within the scatter of the next); then compound 4.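

Hydrogen in place of isopropyl on an aromatic carbon, para to a large group, brings a 3.7-fold higher number from compound 2 to compound 4 (0.57 log units; beyond the scatter) in this assay, which means weaker inhibition. This is the only pair shown that differs in one place, so it gives the first direct reading of this position: the isopropyl group cannot simply be removed without the number changing, and what sits here counts in this assay's read-out. Nothing measured here explains why the number rises, so the step stands as an observation without a known cause.

This single pair leaves open whether other groups at the same position, such as a methyl, a chlorine, an amine or a carboxylic acid, would give a number nearer to that of compound 2 or to that of compound 4. Among these compounds, it also leaves open whether the same change would bring a step of similar size on a compound with a different fluorinated alkoxy group, such as the one carried by compound 1.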